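From cyclooctyl to cyclopentyl on the amine nitrogen

The compounds below may be only part of what the source reports. "The series", "measured", "known", "first", "only" and "open" are said of these compounds alone.

Compound 1 `C=C[C@]1(C)CC[C@@H](C(=C)CNCCCC)C[C@H]1C(=C)C`: 10800 nM
Compound 2 `C=C[C@]1(C)CC[C@@H](C(=C)CNC2CCCCCCC2)C[C@H]1C(=C)C`: 5900 nM
Compound 3 `C=C[C@]1(C)CC[C@@H](C(=C)COCCCC)C[C@H]1C(=C)C`: 266000 nM

In a functional assay on HeLa cells (Homo sapiens) for antiproliferative activity, read by WST assay, with a stated time of 24 h (a lower number here means a stronger inhibitor, a higher number a weaker inhibitor), compound 2 gives 5900 nM. That number sits within the scatter of compound 1, and both lie far from compound 3.

Compound 4 `C=C[C@]1(C)CC[C@@H](C(=C)CNC2CCCC2)C[C@H]1C(=C)C` changes one group: cyclopentyl in place of cyclooctyl on an amine nitrogen. The closest evidence is a 1.8-fold lower number from compound 1 to compound 2 (0.26 log units; within the scatter), a swap of groups on the same amine nitrogen. The much larger a 25-fold higher number from compound 1 to compound 3 (1.39 log units; beyond the scatter) exchanges butylamino for butoxy, whereas compound 4 keeps its amine nitrogen, so that step bears little here. No change beyond the scatter is therefore expected in this assay. The expected size is a 1.4-fold higher number from compound 2 to compound 4 (0.16 log units; within the scatter). For compound 4, the estimated value is 8500 nM, with an expected range of 4000 nM to 18000 nM.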

Compound 4, half-maximal inhibitory concentration: 520 nM
Estimate against measurement, compound 4: 16-fold (1.21 log units) above; measured number below the stated range.
By their numbers in this assay, from the lowest: compound 4; then compounds 2 and 1 (each within the scatter of the next); then compound 3.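

In this assay the choice of group on the amine nitrogen proves able to shift the number strongly: cyclopentyl gives an 11-fold lower number from compound 2 to compound 4 (1.05 log units; beyond the scatter) and also a 21-fold lower number from compound 1 to compound 4 (1.32 log units; beyond the scatter) even though the step between butyl and cyclooctyl stayed within the scatter. Ring or chain alone therefore does not decide the result, and neither does ring size follow a simple trend across these three groups. Keeping a nitrogen and adding this ring gives a 510-fold lower number from compound 3 to compound 4 (2.71 log units; beyond the scatter) as the largest step seen so far.

Nothing measured here explains why cyclopentyl stands out. From the compounds shown here alone, whether cyclobutyl or cyclohexyl on the same nitrogen would match compound 4 remains open.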